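From carboxy to thiophen-2-yl on the chain of compound 3

The compounds below may be only part of what the source reports. "The series", "measured", "known", "first", "only" and "open" are said of these compounds alone.

In a functional assay for inhibition, with Homo sapiens as the target (on this read-out lower numbers stand for stronger inhibition and higher numbers for weaker inhibition), compound 1 `O=C(O)COc1cccc(/C=C\c2nc(-c3ccccc3)c(-c3ccccc3)o2)c1` gives 180 nM. For compound 2 `CCOC(=O)/C(=C\c1cccc(OCC(=O)OC(C)(C)C)c1)c1nc(-c2ccccc2)c(-c2ccccc2)o1` the read-out is only a limit, > 60000 nM. Compound 3 `O=C(O)COc1cccc(CC(C(=O)O)c2nc(-c3ccccc3)c(-c3ccccc3)o2)c1` gives 14000 nM, the higher of the two true numbers and beyond the scatter from compound 1, its nearest neighbour. Compound 4 `O=C(O)COc1cccc(CC(c2nc(-c3ccccc3)c(-c3ccccc3)o2)c2cccs2)c1` carries thiophen-2-yl in place of carboxy on a saturated chain carbon bound to an aromatic carbon and a saturated chain carbon. Within the data shown here, no measured step isolates this change. Compound 1, which lacks that chain carboxy, gives 180 nM, so the number in this assay is expected to fall beyond the scatter, toward stronger inhibition. The expected step is a 14-fold lower number from compound 3 to compound 4 (1.15 log units; beyond the scatter). For compound 4 the estimated value is 1000 nM, with a range of 150 nM to 7000 nM.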

Compound 4, half-maximal inhibitory concentration: 33200 nM
Beside the measured number, compound 4's estimate is 33-fold (1.52 log units) below it; the measured number lies above the stated range.
By their numbers in this assay, from the lowest: compound 1; then compound 3; then compound 4. At a limit, above all of these: compound 2.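

In this assay, thiophen-2-yl in place of carboxy on this saturated chain carbon gives a 2.4-fold higher number from compound 3 to compound 4 (0.38 log units; beyond the scatter). Removing the carboxy here therefore does not by itself bring stronger inhibition, and this aromatic ring leaves the number modestly weaker. Compound 4 still gives a true number, so the step can be read in full, short of the ceiling of the read-out: the limit of > 60000 nM in this assay, at which 1 of the 4 values shown sits.

The compounds shown leave open whether the loss follows from this ring or from any group at this carbon. An amine, a methyl group or a plain hydrogen on the same carbon could separate these readings.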